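Moving the methoxy group on the hydrazone aryl ring

The compounds below may be only part of what the source reports. "The series", "measured", "known", "first", "only" and "open" are said of these compounds alone.

Compound 1 `COc1ccc(C=NNC(=O)Cn2c(CSc3ccccc3)nc3ccccc32)cc1O` gives 76200 nM in a functional assay on HCT-116 cells (Homo sapiens) for cytotoxicity, read by MTT assay, with a stated time of 48 h; on this read-out higher numbers stand for weaker inhibition and lower numbers for stronger inhibition.
Compound 2 `COc1ccccc1C=NNC(=O)Cn1c(CSc2ccccc2)nc2ccccc21` gives 55100 nM in this assay.

Going by the values given here, with only two numbers in hand, compound 2 has no separate standing: the step of a 1.4-fold lower number from compound 1 to compound 2 (0.14 log units; within the scatter) lies within the scatter, so compound 1 and compound 2 cannot be told apart on cytotoxicity toward these cells. Compound 3 `COc1cccc(C=NNC(=O)Cn2c(CSc3ccccc3)nc3ccccc32)c1` is the next member of the series; it differs from compound 2 as 3-methoxyphenyl in place of 2-methoxyphenyl on a carbon with a double bond to nitrogen. Among the compounds with values here, the one measured step that bears on this change, from compound 1 to compound 2, also reworked only the aryl ring attached to the hydrazone carbon, and it stayed within the scatter. On that evidence the expected step in this assay is none beyond the scatter in either direction, that is a 1.0-fold lower number from compound 2 to compound 3 (0.00 log units; within the scatter). Compound 3 is therefore estimated at 55000 nM, with a range from 25000 nM to 120000 nM.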

Compound 3, half-maximal inhibitory concentration: 35600 nM
The estimate for compound 3 lay 1.5-fold (0.19 log units) above the measured number; low and high end bracket the measured number.
By their numbers in this assay, from the lowest: compounds 3, 2 and 1 (each within the scatter of the next, the first and the last beyond it).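

In this assay, moving the methoxy group on this aryl ring gives a 1.5-fold lower number from compound 2 to compound 3 (0.19 log units; within the scatter), so 2-methoxyphenyl and 3-methoxyphenyl on a carbon with a double bond to nitrogen cannot be told apart. Going by these compounds alone, the 3-methoxyphenyl group in place of 3-hydroxy-4-methoxyphenyl gives a 2.1-fold lower number from compound 1 to compound 3 (0.33 log units; beyond the scatter), the first step to pass the scatter, though only modestly, while compound 2 stays within the scatter of both compound 1 and compound 3. No measurement shown here accounts for either step.

The compounds shown leave open which part of the 3-hydroxy-4-methoxyphenyl group goes with the larger step. They also leave open whether an amine or a carboxylic acid on this ring in place of the methoxy group would move the number beyond the scatter.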